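Aryl exchange on the shared core: from compound 3 to compound 4

This account rests on a few compounds, and the source may have more. Where it says the series, first, only, none or still open, it means among the compounds named here.

Compound 3 `C=CCn1c(=O)/c(=C\c2cccc(C)c2)[nH]c(=O)/c1=C\c1ccccc1OC` gives 16700 nM in a functional assay on HL-60 cells (Homo sapiens) for cytotoxicity, read by CCK-8 assay, with a stated time of 72 h (on this read-out higher numbers stand for weaker inhibition and lower numbers for stronger inhibition), the highest number of the three measured. Compound 1 `C=CCn1c(=O)/c(=C\c2ccccc2C(F)(F)F)[nH]c(=O)/c1=C\c1ccccc1OC` gives 4600 nM and compound 2 `C=CCn1c(=O)/c(=C\c2cc(F)ccc2C)[nH]c(=O)/c1=C\c1ccccc1OC` gives 2600 nM; the steps of a 3.6-fold higher number from compound 1 to compound 3 (0.56 log units; beyond the scatter) and a 6.4-fold higher number from compound 2 to compound 3 (0.81 log units; beyond the scatter) both run towards the 3-methylphenyl group, while a 1.8-fold lower number from compound 1 to compound 2 (0.25 log units; within the scatter) is small. Compound 4 `C=CCn1c(=O)/c(=C\c2ccccc2F)[nH]c(=O)/c1=C\c1ccccc1OC` carries the change (2-fluorophenyl in place of 3-methylphenyl on a double-bonded chain carbon bound to an aromatic carbon). Within the data shown here, no measured step involves 2-fluorophenyl, but both steps ending at compound 3 were modest rises, so a modest fall is expected on leaving 3-methylphenyl, of about a 2.8-fold lower number from compound 3 to compound 4 (0.44 log units; beyond the scatter). Compound 4 is therefore estimated at 6000 nM, within the range 2500 nM to 15000 nM.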

Compound 4, half-maximal inhibitory concentration: 18500 nM
For compound 4 the middle estimate is 3.1-fold (0.49 log units) below the measured one; measured number outside the range, above it.
By their numbers in this assay, from the lowest: compounds 2 and 1 (each within the scatter of the next); then compounds 3 and 4 (each within the scatter of the next).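

In this assay, exchanging 3-methylphenyl for 2-fluorophenyl at this position leaves the number unchanged within the scatter: a 1.1-fold higher number from compound 3 to compound 4 (0.04 log units; within the scatter). Fluoro in place of trifluoromethyl on an aromatic carbon does raise it, a 4.0-fold higher number from compound 1 to compound 4 (0.60 log units; beyond the scatter). The 5-fluoro-2-methylphenyl group also stands apart from 2-fluorophenyl, a 7.1-fold higher number from compound 2 to compound 4 (0.85 log units; beyond the scatter), so a fluorine on the ring does not by itself bring a low number.

No supporting measurement accounts for these steps. On these data alone, whether a 2-chlorophenyl group or a carboxylic acid on this ring would lower the number remains open.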